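Replacing the acetoxy group of compound 3

The source may hold more compounds than are shown below. What is called first, only, known or untested is meant among the compounds shown, and "the series" means these compounds.

Compound 1 `OCc1cn(Cc2ccc(Cl)cc2)c2ccccc12`: 16 nM
Compound 2 `OCCc1cn(Cc2ccc(Cl)cc2)c2ccccc12`: > 31600 nM (a limit of the assay, not a number)
Compound 3 `CC(=O)OCc1cn(Cc2ccc(Cl)cc2)c2ccccc12`: 39 nM

In a functional assay on NCI-H460 cells (Homo sapiens) for cytotoxicity, read by sulforhodamine B assay, with a stated time of 3 days (on this read-out lower numbers stand for stronger inhibition and higher numbers for weaker inhibition), compound 3 has the higher of the two true numbers, at 39 nM. It stays close to compound 1, with a 2.4-fold higher number from compound 1 to compound 3 (0.39 log units; beyond the scatter). Compound 4 `COC(=O)CNCc1cn(Cc2ccc(Cl)cc2)c2ccccc12` differs from compound 3 as follows: ((methoxycarbonyl)methyl)amino in place of acetoxy on a saturated chain carbon bound to an aromatic carbon. This places ((methoxycarbonyl)methyl)amino in place of acetoxy on a saturated chain carbon bound to an aromatic carbon. Edits at this spot have given very different results: the modest 2.4-fold higher number from compound 1 to compound 3 (0.39 log units; beyond the scatter), but also the large at least 1900-fold higher number from compound 1 to compound 2 (3.29 log units; beyond the scatter) and an at least 810-fold lower number from compound 2 to compound 3 (2.90 log units; beyond the scatter). Within the data shown here, no measured compound has a nitrogen here, so a substantial rise in the number is expected, with wide uncertainty. The expected step is a 130-fold higher number from compound 3 to compound 4 (2.11 log units; beyond the scatter). For compound 4 the estimate is 5000 nM, within a range of 300 nM to 31000 nM.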

Compound 4, half-maximal inhibitory concentration: 100 nM
Estimate against measurement, compound 4: 50-fold (1.70 log units) above; measured number below the stated range.
By their numbers in this assay, from the lowest: compound 1; then compound 3; then compound 4. At a limit, above all of these: compound 2.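

In this assay, a nitrogen-bearing group is tolerated on this saturated chain carbon: ((methoxycarbonyl)methyl)amino, the larger group, gives only a 2.6-fold higher number from compound 3 to compound 4 (0.41 log units; beyond the scatter), and a 6.3-fold higher number from compound 1 to compound 4 (0.80 log units; beyond the scatter). Bulk alone therefore does not produce the collapse seen with hydroxymethyl, as shown by an at least 310-fold lower number from compound 2 to compound 4 (2.49 log units; beyond the scatter). The value of compound 2 in that step is a limit of the assay, not a number: the limit of > 31600 nM in this assay, at which 1 of the 4 values shown sits.

From the compounds shown here alone, whether the nitrogen or the methyl ester matters more remains open. A simple amine or a carboxylic acid on the same carbon would help separate the two.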